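Ester to aldehyde in a cytotoxicity series

The source may hold more compounds than are shown below. What is called first, only, known or untested is meant among the compounds shown, and "the series" means these compounds.

Compound 1 `C[C@@H]1CC[C@H]2CC3=C(C(=O)O)CC[C@@]31C2(C)C` carries a carboxylic acid on the shared core and in an ADME assay on Raji cells (Homo sapiens) for cytotoxicity, read by CellTiter-Glo, with a stated time of 72 h (a higher number here means that more compound is needed for the effect, a lower number that less compound is needed), compound 1 gives 26000 nM. Compound 2 `COC(=O)C1=C2C[C@@H]3CC[C@@H](C)[C@]2(CC1)C3(C)C` is its methyl ester; in this assay compound 2 gives 26000 nM. Among the compounds with values here, the one step between them, no change at the digits printed from compound 1 to compound 2 (within the scatter), shows that capping the acid as the methyl ester leaves the read-out where it was. On the numbers to hand, compound 2 therefore stands level with compound 1, with no ordering between the two.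

Compound 3 `C[C@@H]1CC[C@H]2CC3=C(C=O)CC[C@@]31C2(C)C` is the next point. It differs from compound 2 as follows: hydrogen in place of methoxy on a carbonyl carbon. Within the data shown here, no measured step touches the carbonyl carbon itself, so only the acid-to-ester step bears on this change, and it was flat. Trimming the methoxycarbonyl to a formyl is taken as a comparable small alteration at the same group, so no movement beyond the scatter is expected in this assay; the expected step is no change at the digits printed from compound 2 to compound 3 (within the scatter). For compound 3 the estimate in this assay is 26000 nM, with a range from 10000 nM to 65000 nM.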

Compound 3, half-maximal effective concentration: 26000 nM
The estimate for compound 3 equals the measured number at the digits printed, within the range that was stated.
By their numbers in this assay, from the lowest: compounds 1, 2 and 3 (each within the scatter of the next).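

In this assay the atom held directly on the carbonyl carbon has now been changed: hydrogen in place of methoxy gives no change at the digits printed from compound 2 to compound 3 (within the scatter), and hydrogen in place of hydroxy gives no change at the digits printed from compound 1 to compound 3 (within the scatter). The earlier step altered only what sits on the oxygen, whereas these two steps remove that oxygen altogether, so the read-out stays level across hydroxy, methoxy and hydrogen on this carbonyl carbon, and the carboxylic acid, the methoxycarbonyl and the formyl cannot be told apart here. No measurement to hand accounts for this flat read-out.

As far as these compounds go, all three compounds keep a carbonyl on the double-bonded ring carbon, so it remains open whether the read-out stays level once that carbonyl is replaced, for instance by a hydroxymethyl group or a nitrile, or when the carbonyl carbon bears nitrogen, as in a primary amide. From the compounds shown here alone, it also remains open whether a longer ester chain, such as a benzyl ester, would stay level with compound 2.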